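Replacing Benzyloxy with Methyl on a Receptor Binder

The source may hold more compounds than are shown below. What is called first, only, known or untested is meant among the compounds shown, and "the series" means these compounds.

Of the compounds shown here, two have so far been tested in an in vitro assay on CHOK cells for displacement of a labelled ligand from growth hormone secretagogue receptor type 1 (Homo sapiens); on this read-out lower numbers stand for stronger inhibition and higher numbers for weaker inhibition. Among the compounds with values here, compound 1 `Nc1nc(N)c(-c2ccc(NCc3ccncc3)cc2)c(COCc2ccccc2)n1` gives 21 nM, while compound 2 `Nc1nc(N)c(-c2ccc(CNc3ccc([N+](=O)[O-])cc3)cc2)c(COCc2ccccc2)n1` gives 0.8 nM, the lowest of the two numbers; the single measured step is a 26-fold lower number from compound 1 to compound 2 (1.42 log units; beyond the scatter). Compound 3 `CCc1nc(N)nc(N)c1-c1ccc(CNc2ccc([N+](=O)[O-])cc2)cc1` has not yet been measured. It differs from compound 2 by methyl in place of benzyloxy on a saturated chain carbon bound to an aromatic carbon. Within the data shown here, no measured step touches this part of the molecule: the only known step alters a different arm of the structure, so it offers no direct guidance on how binding will respond. Among the measured compounds shown here, with no precedent in these data, the change simply removes a larger group and leaves a smaller one, and the expectation is a modest weakening rather than a gain, estimated as a 7.5-fold higher number from compound 2 to compound 3 (0.88 log units; beyond the scatter) in this assay. Compound 3 is therefore estimated at 6 nM, with a plausible range from 1.2 nM to 40 nM.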

Compound 3, half-maximal inhibitory concentration: 9.2 nM
Compound 3: middle estimate off by 1.5-fold (0.19 log units), on the low side; low and high end bracket the measured number.
By their numbers in this assay, from the lowest: compound 2; then compound 3; then compound 1.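

In this assay, this place on the saturated chain carbon bound to an aromatic carbon clearly matters: methyl in place of benzyloxy gives a 12-fold higher number from compound 2 to compound 3 (1.06 log units; beyond the scatter), a step large enough to stand beyond the usual scatter. Still, compound 3 gives 9.2 nM, so binding on this read-out survives the loss of the benzyloxy ring and its oxygen, though it is weaker. Nothing measured here bears on what lies behind this step.

With only benzyloxy and methyl at this place, the compounds shown cannot separate the part played by the ring from that of the oxygen; a methoxy or a phenyl group there would help to tell them apart. On these data alone, how an amine or a longer chain would fare, and whether the step would be the same with the other arm of compound 1, also remains open.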